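Swapping cyclopentylamino for piperidin-1-yl on a carbonyl carbon

The source may hold more compounds than are shown below. What is called first, only, known or untested is meant among the compounds shown, and "the series" means these compounds.

In a functional assay on BXPC-3 cells (Homo sapiens) for cytotoxicity, read by fluorescence, with a stated time of 48 h (a higher number here means that more compound is needed for the effect, a lower number that less compound is needed), compound 1 (`CC(C)=CCC/C(C)=C/CC/C(C)=C/CSC[C@H](NC(=O)CCCCCN1CCCC1)C(=O)NC1CCCCC1`) gives 12700 nM, compound 2 (`CC(C)=CCC/C(C)=C/CC/C(C)=C/CSC[C@H](NC(=O)CCCCCN1CCCC1)C(=O)NC1CCCC1`) gives 6800 nM and compound 3 (`CC(C)=CCC/C(C)=C/CC/C(C)=C/CSC[C@H](NC(=O)CCCCCN1CCN(C)CC1)C(=O)NC1CCCCCCC1`) gives 7500 nM. Compound 2 therefore stands level with the other two, since its value lies within the usual scatter of both and no order can be claimed.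

Compound 4 (`CC(C)=CCC/C(C)=C/CC/C(C)=C/CSC[C@H](NC(=O)CCCCCN1CCCC1)C(=O)N1CCCCC1`) has the same atoms as compound 2, joined differently: piperidin-1-yl in place of cyclopentylamino on a carbonyl carbon. Put simply, this is piperidin-1-yl in place of cyclopentylamino on a carbonyl carbon, and the amide hydrogen is lost.

Within the data shown here, one measured step bears on this change. Shrinking the carbon ring on the amide gave a 1.9-fold lower number from compound 1 to compound 2 (0.27 log units; within the scatter). That step shows a ring swap on this amide staying within the scatter, but both of its compounds keep the amide hydrogen. Among the measured compounds shown here, no measured compound lacks that hydrogen, so this part of the change is untested.

A step beyond the scatter is thus not expected in this assay, although the range must stay wide. The estimated step is a 1.3-fold higher number from compound 2 to compound 4 (0.12 log units; within the scatter). For compound 4 the estimate is 9000 nM, with an expected range from 4000 nM to 20000 nM.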

Compound 4, half-maximal effective concentration: 8700 nM
Compound 4: middle estimate off by 1.0-fold (0.01 log units), on the high side; low and high end bracket the measured number.
By their numbers in this assay, from the lowest: compounds 2, 3, 4 and 1 (each within the scatter of the next).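

In this assay, a compound without the amide hydrogen now has a measured number: the swap to piperidin-1-yl gives a 1.3-fold higher number from compound 2 to compound 4 (0.11 log units; within the scatter) and, set against the cyclohexylamino compound, it gives a 1.5-fold lower number from compound 1 to compound 4 (0.16 log units; within the scatter) as well. Among these compounds, on this carbonyl carbon, then, an amide nitrogen held inside a six-membered ring and carrying no hydrogen stays level with both compounds that carry one, something the earlier compounds could not show because all of them kept that hydrogen. Nothing measured on hand explains this result, so the numbers say only that no difference can be seen here, not why.

The compounds shown leave open whether other groups without the amide hydrogen, such as morpholin-4-yl or dimethylamino, would also stay within the scatter on this carbonyl carbon. They also leave open what a plain amino group or a hydroxyl in the same place, the latter giving a carboxylic acid, would do to the number, and whether the piperidin-1-yl swap would read the same on a compound with a longer chain.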